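The source may report more compounds than this note shows. Statements on the series, on what has been measured and on what is new or still open speak of the compounds shown alone.

Compound 1, `O=C1/C(=C/c2cccnc2)CN(S(=O)(=O)c2ccccc2)C/C1=C\c1ccccc1F`, and compound 2, `O=C1/C(=C/c2cccnc2)CN(S(=O)(=O)c2ccc([N+](=O)[O-])cc2)C/C1=C\c1ccccc1F`, share one core and differ by nitro in place of hydrogen on an aromatic carbon. In an ADME assay on L02 cells (Homo sapiens) for cytotoxicity, read by MTT assay, with a stated time of 24 h (on this read-out higher numbers stand for weaker inhibition and lower numbers for stronger inhibition), compound 1 gives 15300 nM. For compound 2 this assay reports only a limit, > 20000 nM, so no exact number is known for it. The step of an at least 1.3-fold higher number from compound 1 to compound 2 (0.11 log units; that floor lies within the scatter) rests on that bound, (the limit of > 20000 nM in this assay, at which 1 of the 2 values shown sits), and does not rise beyond the scatter. Compound 3, `O=C1/C(=C/c2cccnc2)CN(S(=O)(=O)c2ccc(Cl)cc2)C/C1=C\c1ccccc1F`, has not yet been measured in this assay; it differs from compound 2 as chloro in place of nitro on an aromatic carbon. Among the compounds with values here, the only measured step that touches the same aromatic carbon is this one from compound 1 to compound 2, and it showed no clear movement, so there is no basis for expecting a large shift in either direction; both measured compounds sit at the weak end of this assay. Compound 3 is therefore expected to give about 18000 nM, with a range from 8000 nM to 40000 nM. The estimated step of an at least 1.1-fold lower number from compound 2 to compound 3 (0.04 log units; that floor lies within the scatter) states the same expectation.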

Compound 3, half-maximal inhibitory concentration: > 20000 nM
Compound 3: only a limit was reported; the forecaster's own chance of this, stated with the estimate: 40%; at least 1.1-fold (0.04 log units) between middle value and limit.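

In this assay compound 3 is reported only as a limit, > 20000 nM. The result gives an at least 1.3-fold higher number from compound 1 to compound 3 (0.11 log units; that floor lies within the scatter), the same floor as an at least 1.3-fold higher number from compound 1 to compound 2 (0.11 log units; that floor lies within the scatter), so a second group on this aromatic carbon, para to a large group, also shows no movement beyond the scatter from the unsubstituted compound, whether that group is the single heavy atom of chloro or the three heavy atoms of nitro. The step between compound 2 and compound 3 cannot be read, so chloro and nitro cannot be ordered against each other, and the new information is only that both end at the same ceiling of the read-out: the limit of > 20000 nM in this assay, at which 2 of the 3 values shown sit.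

The compounds shown leave open how far the true numbers of compound 2 and compound 3 lie past that limit, and so whether either one really differs from compound 1 by more than the scatter. They also leave open whether an amine or a carboxylic acid on this same aromatic carbon would give a number that moves clearly away from that of compound 1, in either direction.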